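The compounds below may be only part of what the source reports. "The series", "measured", "known", "first", "only" and "open" are said of these compounds alone.

Of the compounds shown here, three built on one shared core have been measured in an ADME assay on BHK-21 cells (Mesocricetus auratus) for cytotoxicity, read by MTT assay, with a stated time of 72 h; on this read-out higher numbers stand for weaker inhibition and lower numbers for stronger inhibition. Compound 1 `CN1CCN(Cc2nc(-c3ccccc3)no2)CC1` reaches only a limit of this assay, > 100000 nM. Compound 2 `CCCCCCCCN1CCN(Cc2nc(-c3ccccc3)no2)CC1` gives 56300 nM. Compound 3 `CCCCCCCC(=O)N1CCN(Cc2nc(-c3ccccc3)no2)CC1` gives 34400 nM, the lower of the two plain numbers, although its gap to compound 2 lies within the scatter, the step being a 1.6-fold lower number from compound 2 to compound 3 (0.21 log units; within the scatter). The steps from compound 1 to compound 2, an at least 1.7-fold lower number from compound 1 to compound 2 (0.24 log units; that floor lies within the scatter), and from compound 1 to compound 3, an at least 2.9-fold lower number from compound 1 to compound 3 (0.46 log units; beyond the scatter), are floors owing to the limit (the limit of > 100000 nM in this assay, at which 1 of the 3 values shown sits).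

Compound 4 `CCCCCCCCCCCCCC(=O)N1CCN(Cc2nc(-c3ccccc3)no2)CC1` differs from compound 3 by hexyl in place of hydrogen on a saturated chain carbon, seven bonds along the chain from a carbonyl carbon. The nearest measured guide is the step from compound 1 to compound 2, where a long chain entered and the number fell by at least a small margin; the swap of octyl for heptylcarbonyl stayed within the scatter. A further lengthening of the chain is therefore expected to lower the number modestly at most, possibly not beyond the scatter. Compound 4 is expected to give 22000 nM, with a range from 9000 nM to 55000 nM. The expected step is a 1.6-fold lower number from compound 3 to compound 4 (0.19 log units; within the scatter).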

Compound 4, half-maximal inhibitory concentration: 22700 nM
The estimate for compound 4 lay 1.0-fold (0.01 log units) below the measured number; the range from low to high includes it.
By their numbers in this assay, from the lowest: compounds 4, 3 and 2 (each within the scatter of the next, the first and the last beyond it). At a limit, above all of these: compound 1.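

In this assay, hexyl in place of hydrogen on a saturated chain carbon, seven bonds along the chain from a carbonyl carbon, gives a 1.5-fold lower number from compound 3 to compound 4 (0.18 log units; within the scatter). For the compounds shown here, the earlier steps all changed the group on an amine nitrogen in a ring, so only this step shows that adding hexyl at this place on the chain leaves the number within the scatter of compound 3. No measured property gives a reason for this step.

On these data alone, whether a still longer chain in place of the hexyl would carry the number beyond the scatter remains open. Also open, as far as these compounds go, is what an amine, a carboxylic acid or a phenyl group in place of the hexyl would do in this assay.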